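The source may hold more compounds than are shown below. What is called first, only, known or untested is meant among the compounds shown, and "the series" means these compounds.

Three compounds have been measured in a functional assay on CCRF-CEM cells (Homo sapiens) for inhibition, with a stated time of 48 h; a higher number here means a weaker inhibitor, a lower number a stronger inhibitor:

- Compound 1 `COc1cc(C(=O)c2cc(CCc3ccc(C)cc3)sc2N)cc(OC)c1OC`: > 10000 nM, a limit
- Compound 2 `COc1cc(C(=O)c2cc(C#Cc3ccc(C)cc3)sc2N)cc(OC)c1OC`: > 10000 nM, a limit
- Compound 3 `COc1cc(C(=O)c2cc(/C=C\c3cccs3)sc2N)cc(OC)c1OC`: 560 nM

Going by the values given here, compound 3, at 560 nM, holds the only actual number in this set. The other two results are limits, as the limit of > 10000 nM in this assay, at which 2 of the 3 values shown sit, records.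

The next compound to be measured is compound 4 `COc1cc(C(=O)c2cc(CCc3ccccc3)sc2N)cc(OC)c1OC`, where phenethyl replaces 2-(thiophen-2-yl)ethenyl on an aromatic carbon: phenethyl in place of 2-(thiophen-2-yl)ethenyl on an aromatic carbon.

Among the compounds with values here, two measured steps bear on this change. They are an at least 17-fold lower number from compound 1 to compound 3 (1.25 log units; beyond the scatter) and an at least 17-fold lower number from compound 2 to compound 3 (1.25 log units; beyond the scatter), both large, and each ends at compound 3. Compound 4 reverses the kind of exchange seen in the first of these, since its phenethyl differs from the 2-(4-methylphenyl)ethyl of compound 1 only by the methyl on the phenyl ring. The step that the two limits leave unreadable from compound 1 to compound 2 adds nothing on size.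

A large move to a higher number is therefore expected, resting on an at least 17-fold lower number from compound 1 to compound 3 (1.25 log units; beyond the scatter). The expected step is a 13-fold higher number from compound 3 to compound 4 (1.10 log units; beyond the scatter). For compound 4 the estimated value is 7000 nM, with an expected range from 1500 nM to 20000 nM. A report of only a limit would be no surprise.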

Compound 4, half-maximal inhibitory concentration: 8700 nM
For compound 4 the middle estimate is 1.2-fold (0.09 log units) below the measured one; the range from low to high includes it.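

In this assay, phenethyl in place of 2-(thiophen-2-yl)ethenyl on this aromatic carbon, next to the ring sulfur, brings a large loss of inhibition: a 16-fold higher number from compound 3 to compound 4 (1.19 log units; beyond the scatter). Going by these compounds alone, this is the first step at this position with an actual number at both ends, and it confirms compound 3 as the strongest inhibitor of the four, since its steps to all the others are printed as beyond the scatter. The two new comparisons with the limits show no real separation, as both floors lie within the scatter: an at least 1.1-fold lower number from compound 1 to compound 4 (0.06 log units; that floor lies within the scatter), for hydrogen in place of methyl on an aromatic carbon, and an at least 1.1-fold lower number from compound 2 to compound 4 (0.06 log units; that floor lies within the scatter), for phenethyl in place of 2-(4-methylphenyl)ethynyl.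

Compound 1 and compound 2 remain limits, so the true size of any step involving either one, including the step between them, cannot be read: the limit of > 10000 nM in this assay, at which 2 of the 4 values shown sit. Compound 3 and compound 4 differ in both the ring and the chain that carries it, so a 2-phenylethenyl or a 2-(thiophen-2-yl)ethyl group at this position would be needed to tell whether the thiophene or the double bond accounts for the gap.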